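Compound 2: methoxy to isopropoxy

The source may report more compounds than this note shows. Statements on the series, on what has been measured and on what is new or still open speak of the compounds shown alone.

Two values stand so far in the series. In a functional assay on thoracic aorta (Rattus norvegicus, strain Wistar), with a stated time of 15 min (on this read-out higher numbers stand for an effect only at larger amounts of compound and lower numbers for an effect already at smaller amounts), compound 1 (`Cc1ccc(S(=O)(=O)N(C)C(=O)NC(C)c2cc(Br)ccc2OC(C)C)cc1`) gives 34700 nM as its half-maximal effective concentration. Compound 2 (`COc1ccc(Br)cc1C(C)NC(=O)N(C)S(=O)(=O)c1ccc(Cl)cc1`) gives 19100 nM on the same read-out, and this number lies within the usual scatter of the number for compound 1, so the two cannot be told apart.

The next structure is compound 3 (`CC(C)Oc1ccc(Br)cc1C(C)NC(=O)N(C)S(=O)(=O)c1ccc(Cl)cc1`). It differs from compound 2 by methoxy to isopropoxy, that is, isopropyl in place of methyl on an oxygen on an aromatic ring with the rest unchanged. Going by the values given here, no measured pair shows this change on its own. In this assay, among the compounds with values here, no step beyond the scatter is expected and no direction is favoured, the only guide being that compound 1 at 34700 nM and compound 2 at 19100 nM sit within the scatter of each other. The estimate expects a 1.3-fold higher number from compound 2 to compound 3 (0.12 log units; within the scatter) as a small step. For compound 3 the estimated value is 25000 nM with an expected range from 9000 nM to 70000 nM on this estimate.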

Compound 3, half-maximal effective concentration: 43200 nM
Compound 3: middle estimate off by 1.7-fold (0.24 log units), on the low side; low and high end bracket the measured number.
By their numbers in this assay, from the lowest: compounds 2, 1 and 3 (each within the scatter of the next, the first and the last beyond it).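

In this assay, the replacement of methoxy by isopropoxy now has a step of its own, with the rest of the structure unchanged: a 2.3-fold higher number from compound 2 to compound 3 (0.35 log units; beyond the scatter). Going by these compounds alone, this is the first step beyond the scatter, so the group on this oxygen can shift the read-out, although the size is modest and rests on a single pair. The other new pair tests chloro in place of methyl on an aromatic carbon with isopropoxy held in place, and a 1.2-fold higher number from compound 1 to compound 3 (0.10 log units; within the scatter) leaves compound 1 and compound 3 indistinguishable, so this change has no readable effect in this setting; nothing available bears on what lies behind either result.

The compounds shown include no methoxy partner of compound 1, so it remains open whether the isopropoxy step also holds with methyl on the aromatic carbon. Also open, as far as these compounds go, is how the read-out responds to other groups on the same oxygen, such as ethyl, a longer propyl or butyl chain, or a chain ending in an amine or a carboxylic acid.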